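The source may report more compounds than this note shows. Statements on the series, on what has been measured and on what is new or still open speak of the compounds shown alone.

Measured compounds in an assay on mitochondria (strain BALB/c) for inhibition of glycerol-3-phosphate acyltransferase 1, mitochondrial (Mus musculus), read by scintillation counting, with a stated time of 10 min; on this read-out lower numbers stand for stronger inhibition and higher numbers for weaker inhibition:
compound 1, `CCCCCCCCS(=O)(=O)Nc1cc(/C=C/c2ccc(OC)cc2)ccc1C(=O)O`, 38700 nM
compound 2, `CCCCCCCCS(=O)(=O)Nc1ccc(/C=C/c2ccc(OC)cc2)cc1C(=O)O`, 37100 nM
compound 3, `CCCCCCCCS(=O)(=O)Nc1cc(CCc2ccccc2)ccc1C(=O)O`, 37500 nM

Compound 1 and compound 2 share the same atoms joined differently; how their two cores differ is not broken down here. Compound 3 arises from compound 1 by the change (phenethyl in place of 2-(4-methoxyphenyl)ethenyl on an aromatic carbon), and that step gives a 1.0-fold lower number from compound 1 to compound 3 (0.01 log units; within the scatter). Compound 4, `CCCCCCCCS(=O)(=O)Nc1ccc(CCc2ccccc2)cc1C(=O)O`, is the counterpart on the core of compound 2, made by the change (phenethyl in place of 2-(4-methoxyphenyl)ethenyl on an aromatic carbon). It is the same kind of change, but the place differs: in compound 3 the phenethyl sits meta to a large group and para to a carboxy group, in compound 4 meta to a carboxy group and para to a large group. Because a 1.0-fold lower number from compound 1 to compound 3 (0.01 log units; within the scatter) stayed within the scatter, the step for compound 4 is expected to be about a 1.0-fold lower number from compound 2 to compound 4 (0.00 log units; within the scatter). Compound 4 is therefore estimated at 37000 nM, expected between 20000 nM and 70000 nM.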

Compound 4, half-maximal inhibitory concentration: 37500 nM
For compound 4 the middle estimate is 1.0-fold (0.01 log units) below the measured one, and the stated range covers the measured number.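

In this assay, phenethyl in place of 2-(4-methoxyphenyl)ethenyl gives a 1.0-fold higher number from compound 2 to compound 4 (0.00 log units; within the scatter), and the change thus behaves on the core of compound 2 as it does on the core of compound 1: the same change on two cores in this assay, a 1.0-fold lower number (0.01 log units; within the scatter) from compound 1 to compound 3 and a 1.0-fold higher number (0.00 log units; within the scatter) from compound 2 to compound 4, 1.0-fold (0.02 log units) apart, within the scatter of two such steps. Neither step moves the number beyond the scatter, so the agreement shows only a change without a readable effect on both cores. It does not show that a change with a larger effect would carry across in the same way, nor what the loss of the methoxy group and of the double bond would each do alone. The compounds shown leave open whether a shorter or longer chain on the sulfonyl group, or an amine in place of the carboxy group, would shift the number beyond the scatter on either core.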